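The compounds below may be only part of what the source reports. "The series", "measured", "known", "first", "only" and "open" are said of these compounds alone.

The compounds share one core, shown first by compound 1 `COc1cc(NC(C)CCCNC(=O)/C=C/c2ccccc2F)c2ncccc2c1`. Among the compounds with values here, compound 1 is the only member of the group with a number: in an ADME assay on L6 cells (Rattus norvegicus) for cytotoxicity, read by resazurin assay, with a stated time of 70 h (a lower number here means a stronger inhibitor, a higher number a weaker inhibitor), compound 1 gives 3500 nM. Compound 2 `COc1cc(NC(C)CCCNC(=O)Nc2ccc(Cl)c(C(F)(F)F)c2)c2ncccc2c1` carries a urea in place of the unsaturated amide of compound 1, and in this assay compound 2 gives "not determined" (no result reported). Compound 3 `COc1cc(NC(C)CCCNC(=O)NNC(=O)NCCCO)c2ncccc2c1` lengthens the tail into a two-part urea ending in a 3-hydroxypropyl group; in this assay compound 3 gives "not determined" (no result reported), so compound 3 stands without a number, as does compound 2, and only compound 1 offers a figure to lean on. Compound 4 `COc1cc(NC(C)CCCNC(=O)NNC(=O)Nc2ccc(C(F)(F)F)cc2)c2ncccc2c1` is compound 3 with a single change: 4-(trifluoromethyl)phenyl in place of 3-hydroxypropyl on an amide-type nitrogen. Within the data shown here, no measured pair shows what this exchange does to the toxicity reading, so no direction can be drawn from the data. Among the measured compounds shown here, with no step to go by, the expectation for compound 4 rests on compound 1 at 3500 nM, taken as a rough anchor for the whole series. Compound 4 is therefore expected to give about 5000 nM in this assay, with a plausible range from 1000 nM to 30000 nM, and a reading that is only a limit would not be surprising.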

Compound 4, half-maximal inhibitory concentration: 14900 nM
Estimate against measurement, compound 4: 3.0-fold (0.47 log units) below; the measured number falls inside the stated range.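

In this assay, within the data shown here, compound 4 gives 14900 nM but compound 3 has no number to set beside it, so no step from compound 3 to compound 4 can be read. The compounds shown leave open what exchanging 3-hydroxypropyl for 4-(trifluoromethyl)phenyl does by itself in this assay and no evidence at hand bears on the reading of compound 4.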